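The compounds below may be only part of what the source reports. "The series", "measured", "known", "first", "only" and "open" are said of these compounds alone.

Series notes. Compound 2 `CN1CCN(CCCS(=O)(=O)c2ccc3nc(NC(=O)NC(=O)c4cc(-n5cccn5)ccc4Cl)sc3c2)CC1` gives 0.67 nM in an assay on HEK293 cells for displacement of a labelled ligand from growth hormone secretagogue receptor type 1 (Homo sapiens), with a stated time of 60 min (on this read-out higher numbers stand for weaker inhibition and lower numbers for stronger inhibition), the lowest number among the three measured compounds. Compound 1 `CCN(CC)CCCS(=O)(=O)c1ccc2nc(NC(=O)NC(=O)c3cc(-n4cccn4)ccc3Cl)sc2c1` gives 3.9 nM in this assay, and compound 3 `CN1CCC(S(=O)(=O)c2ccc3nc(NC(=O)NC(=O)c4cc(-n5cccn5)ccc4Cl)sc3c2)CC1` gives 15 nM. All measured steps concern the group on the sulfonyl sulfur: a 5.8-fold lower number from compound 1 to compound 2 (0.76 log units; beyond the scatter), a 3.8-fold higher number from compound 1 to compound 3 (0.59 log units; beyond the scatter), and a 22-fold higher number from compound 2 to compound 3 (1.35 log units; beyond the scatter). Compound 4 `Cc1cc(C)n(-c2ccc(Cl)c(C(=O)NC(=O)Nc3nc4ccc(S(=O)(=O)CCCN5CCN(C)CC5)cc4s3)c2)n1` keeps the sulfonyl side of compound 2 unchanged and differs at the other end of the molecule: 3,5-dimethyl-1H-pyrazol-1-yl in place of 1H-pyrazol-1-yl on an aromatic carbon, on an aromatic carbon of a six-membered aromatic ring of carbon only, para to the chloro group. Going by the values given here, none of the measured steps touches this pyrazole ring, so no measured step bears directly on the change, and the size of its effect in this assay is not anchored by any pair. The expectation for compound 4 therefore rests on compound 2 alone, with an expected step of a 2.2-fold higher number from compound 2 to compound 4 (0.35 log units; beyond the scatter), kept small and leaning toward a somewhat higher number. Compound 4 is estimated at 1.5 nM, within a range from 0.3 nM to 8 nM.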

Compound 4, half-maximal inhibitory concentration: 1.3 nM
Beside the measured number, compound 4's estimate is 1.2-fold (0.06 log units) above it; the measured number falls inside the stated range.
By their numbers in this assay, from the lowest: compounds 2 and 4 (each within the scatter of the next); then compound 1; then compound 3.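

In this assay, going by these compounds alone, the one change away from the sulfonyl side gives a 1.9-fold higher number from compound 2 to compound 4 (0.29 log units; within the scatter) and so leaves the read-out within the scatter, whereas every earlier step, all of them at the sulfonyl sulfur, lay beyond it. On the six-membered aromatic ring, para to the chloro group, 3,5-dimethyl-1H-pyrazol-1-yl with 7 heavy atoms therefore cannot be told apart from 1H-pyrazol-1-yl with 5 on this read-out. Nothing available explains this result.

From the compounds shown here alone, it remains open whether the same holds for larger groups on the pyrazole, such as trifluoromethyl or phenyl, or for another ring in its place, such as imidazole or triazole. Going by these compounds, it is also open whether the 3,5-dimethyl-1H-pyrazol-1-yl change behaves alike with the diethylamino chain of compound 1 or the 1-methylpiperidin-4-yl group of compound 3.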